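This account rests on a few compounds, and the source may have more. Where it says the series, first, only, none or still open, it means among the compounds named here.

Compound 1 `CN1CCC[C@H]1COc1cccc([N+](=O)[O-])c1`: 31.2 nM in an assay on membranes from Cerebral cortex for displacement of a labelled ligand from Neuronal acetylcholine receptor; alpha4/beta2 (Rattus norvegicus), with a stated time of 30 min; on this read-out lower numbers stand for stronger inhibition and higher numbers for weaker inhibition
Compound 2 `CN1CCC[C@H]1COc1cccc(C#CCCCCO)c1`: 4400 nM
Compound 3 `CN1CCC[C@H]1COc1cc(O)cc(-c2ccccc2)c1`: 528 nM

Among these three, compound 1 gives the lowest number in this assay; compound 3 lies a clear way above it, and compound 2 lies furthest. Among the measured compounds shown here, the single one-place step recorded, a 140-fold higher number from compound 1 to compound 2 (2.15 log units; beyond the scatter), concerns exchange of the nitro group itself and does not touch the change now considered. Compound 4 `CN1CCC[C@H]1COc1cc(Br)cc([N+](=O)[O-])c1` differs from compound 1 only in this: bromo in place of hydrogen on an aromatic carbon. For the measured compounds named here, no measured step with a bromo group exists, so nothing directly bears on it; the values of compound 2 and compound 3 show only that large alterations of the aromatic ring weaken binding. A modest shift is therefore expected, a 1.9-fold higher number from compound 1 to compound 4 (0.28 log units; within the scatter), with compound 4 estimated at 60 nM (range 15 nM to 250 nM).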

Compound 4, inhibition constant: 55 nM
The estimate for compound 4 lay 1.1-fold (0.04 log units) above the measured number; the range from low to high includes it.
By their numbers in this assay, from the lowest: compounds 1 and 4 (each within the scatter of the next); then compound 3; then compound 2.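

In this assay, bromo in place of hydrogen on this aromatic carbon, meta to a nitro group, gives a 1.8-fold higher number from compound 1 to compound 4 (0.25 log units; within the scatter), so this position accepts one added bromine atom without a change beyond the scatter. Among the compounds shown here, the only earlier one-place step concerned the nitro group itself, so this is the first such reading at this ring position. Nothing available explains the result.

Going by these compounds, whether an amine or a carboxylic acid on the same carbon would also leave the number within the scatter remains open. On these data alone, it is also open whether bromo would give the same result if the nitro group were exchanged for another group.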